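Compound 2 to compound 3: a small expected shift

The compounds below may be only part of what the source reports. "The series", "measured", "known", "first", "only" and "open" are said of these compounds alone.

In a physicochemical assay for lipophilicity, read by HPLC, in phosphate buffer, measured as octanol-water partition, with stated times of 30 min and 48 h, at pH 7.4 (on this read-out lower numbers stand for lower lipophilicity and higher numbers for higher lipophilicity), compound 1 (`CCCC(CCC)C(=O)N(C)/N=N/c1ccc(C(=O)OC)cc1`) gives 4.7 and compound 2 (`CCCC(=O)N(C)/N=N/c1ccc(C#N)cc1`) gives 3.19 as the lower of the two numbers, and the gap between them lies beyond the usual scatter. The two compounds differ in more than one place, so this gap gives no measure of any single change. Compound 3 (`CC(C)C(=O)N(C)/N=N/c1ccc(C#N)cc1`) carries isopropyl in place of propyl on a carbonyl carbon with the same atoms joined differently. Among the measured compounds shown here, no measured pair shows this change, so the expectation rests on the structural change alone. A small downward step in this assay is expected, with a number 0.14 log units lower from compound 2 to compound 3 (within the scatter) as the estimate, a size that would stay within the scatter. For compound 3 the estimated value is 3.05 with an expected range of 2.75 to 3.3 for the coming measurement.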

Compound 3, distribution coefficient: 2.95
The estimate for compound 3 lay 0.10 log units above the measured number; low and high end bracket the measured number.
By their numbers in this assay, from the lowest: compounds 3 and 2 (each within the scatter of the next); then compound 1.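

In this assay, among the compounds shown here, isopropyl in place of propyl on a carbonyl carbon gives a number 0.24 log units lower from compound 2 to compound 3 (within the scatter), the first reading of a single change. On this read-out, compound 2 and compound 3 therefore cannot be told apart at this position, although the same atoms are joined differently; the gap to compound 1, which differs in more than one place, could not show this. No evidence on hand bears on the reason for this result.

Still open, as far as these compounds go, is whether a longer chain such as pentyl, or a cyclopropyl ring, in this place on the carbonyl carbon would give a step beyond the scatter. Also open, from the compounds shown here alone, is whether the exchange of propyl for isopropyl reads the same way when a methyl ester stands in place of the nitrile.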